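Replacing a cyano with methyl on the chain of compound 2

The source may report more compounds than this note shows. Statements on the series, on what has been measured and on what is new or still open speak of the compounds shown alone.

Three compounds from one series share a common core carrying two chlorophenyl groups and a nitrile, differing only in the group attached to the ring nitrogen. Compound 1 `N#Cc1c(-c2ccc(Cl)cc2)cc(-c2ccc(Cl)cc2)n([C@@H]2O[C@H](CO)[C@@H](O)[C@H](O)[C@H]2O)c1=O` bears a sugar on that nitrogen, and in a functional assay on HepG2 cells (Homo sapiens) for cytotoxicity, read by sulforhodamine B assay, with a stated time of 48 h (a higher number here means a weaker inhibitor, a lower number a stronger inhibitor), compound 1 gives 16.1 ug/mL. Compound 2 `N#CCn1c(-c2ccc(Cl)cc2)cc(-c2ccc(Cl)cc2)c(C#N)c1=O` carries a cyanomethyl group instead; in this assay compound 2 is reported as "not active" (no number reported), with no number given, so it stands outside the measured range of compound 1 and cannot be placed on the same scale. Compound 3 `CCn1c(-c2ccc(Cl)cc2)cc(-c2ccc(Cl)cc2)c(C#N)c1=O` is the next member, and it is not yet measured in this assay. The change from compound 2 to compound 3 is methyl in place of cyano on a saturated chain carbon bound to an aromatic nitrogen. For the measured compounds named here, no measured step accompanies this change, so its direction cannot be read from the data; since compound 2 gave no number at all, any step for compound 3 in this assay remains open, with a modest move in either direction, or none beyond the scatter, all possible. Compound 3 is expected to give about 60 ug/mL in this assay, estimated to lie between 20 ug/mL and 200 ug/mL.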

Compound 3, half-maximal inhibitory concentration: 22.3 ug/mL
Compound 3: middle estimate off by 2.7-fold (0.43 log units), on the high side; the range from low to high includes it.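

In this assay, for the compounds shown here, compound 3, with ethyl on the aromatic nitrogen, gives 22.3 ug/mL, so this position can carry a simple chain and still yield a number, whereas compound 2, with cyanomethyl at the same place, is reported as not active; with no number for compound 2, no step between the two can be read. The sugar and ethyl are not separated in this assay, since the change gives a 1.4-fold higher number from compound 1 to compound 3 (0.14 log units; within the scatter), and the reading at this position therefore does not distinguish these two groups. Nothing available gives a reason for the contrast between cyanomethyl and ethyl or for the match between ethyl and the sugar.

The compounds shown leave open whether the loss of a number for compound 2 belongs to the nitrile itself or to the cyanomethyl group as a whole, which a chain ending in an amine or a carboxylic acid could help to separate. They also leave open how a longer chain such as butyl, or a plain methyl on the same nitrogen, would read in this assay.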